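Halogen swap on the pyridine amide of compound 3

The source may hold more compounds than are shown below. What is called first, only, known or untested is meant among the compounds shown, and "the series" means these compounds.

Among the measured members of the series, compound 3 `O=C(CSc1nnc(NC(=O)CCl)s1)Nc1ccc(Cl)cn1` gives 5700 nM in a functional assay on NCI-H460 cells (Homo sapiens) for antiproliferative activity, read by MTT assay, with a stated time of 48 h (a lower number here means a stronger inhibitor, a higher number a weaker inhibitor), the lowest of the two numbers reported. Its nearest neighbour, compound 1 `O=C(CSc1nnc(NC(=O)c2c(Cl)cccc2Cl)s1)Nc1ccc(Br)cn1`, gives 16800 nM in this assay. Compound 2 `COc1ccccc1C(=O)Nc1nnc(SCC(=O)Nc2ccc(Br)cn2)s1` reaches only a limit in this assay, at > 80000 nM (the limit of > 80000 nM in this assay, at which 1 of the 3 values shown sits). Among the measured compounds shown here, the one measured step, an at least 4.7-fold higher number from compound 1 to compound 2 (0.67 log units; beyond the scatter), concerns the aryl on the carbonyl carbon, not the pyridine. Compound 4 `O=C(CSc1nnc(NC(=O)CCl)s1)Nc1ccc(Br)cn1` differs from compound 3 by bromo in place of chloro on an aromatic carbon of the six-membered aromatic ring with one nitrogen, two atoms from the ring nitrogen. For the measured compounds named here, no measured step touches that position, so no step beyond the scatter is expected in this assay, the expected step being a 1.1-fold higher number from compound 3 to compound 4 (0.02 log units; within the scatter). Compound 4 is estimated at 6000 nM, between 2500 nM and 15000 nM.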

Compound 4, half-maximal inhibitory concentration: 7500 nM
The estimate for compound 4 lay 1.3-fold (0.10 log units) below the measured number; low and high end bracket the measured number.
By their numbers in this assay, from the lowest: compounds 3 and 4 (each within the scatter of the next); then compound 1. At a limit, above all of these: compound 2.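

At the 5-chloropyridin-2-yl to 5-bromopyridin-2-yl change, the halogen swap does not separate the two compounds in this assay (a 1.3-fold higher number from compound 3 to compound 4 (0.12 log units; within the scatter)). With 5-bromopyridin-2-yl held fixed, chloromethyl on the carbonyl carbon gives lower numbers than either aryl group (a 2.2-fold lower number from compound 1 to compound 4 (0.35 log units; beyond the scatter); an at least 10-fold lower number from compound 2 to compound 4 (1.02 log units; beyond the scatter)), the second step resting on an assay limit. Nothing measured here gives a cause for these steps.

Open, as far as these compounds go, is whether an amine or a carboxylic acid on that aromatic carbon would stay level with the two halogens. Also open, from the compounds shown here alone, is how a longer chain in place of chloromethyl would read.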